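This account rests on a few compounds, and the source may have more. Where it says the series, first, only, none or still open, it means among the compounds named here.

Of the compounds shown here, three have been tested in a functional assay on HCT-116 cells (Homo sapiens) for inhibition, read by MTT assay, with a stated time of 24 h, tested at 10 uM; a lower number here means less inhibition of growth, a higher number more inhibition of growth at the concentration tested. Compound 1 `CS(=O)(=O)c1ccc(-c2cnc3[nH]cc(-c4nnc(-c5ccccc5)o4)c(=O)c3c2)cc1` gives 15.7%, compound 2 `CS(=O)(=O)c1ccc(-c2cnc3[nH]cc(-c4nnc(-c5ccc(Cl)cc5)o4)c(=O)c3c2)cc1` gives 17%, and compound 3 `O=c1c(-c2nnc(-c3ccc(Cl)cc3)o2)c[nH]c2ncc(-c3ccccc3)cc12` gives 21.6%. Compound 2 sits in the middle of these three numbers, and both neighbours lie within the scatter of it: a number 1.3 percentage points higher from compound 1 to compound 2 (within the scatter), and a number 4.6 percentage points higher from compound 2 to compound 3 (within the scatter). Compound 4 `Cc1cccc(-c2nnc(-c3c[nH]c4ncc(-c5ccc(S(C)(=O)=O)cc5)cc4c3=O)o2)c1` differs from compound 2 in one place: 3-methylphenyl in place of 4-chlorophenyl on an aromatic carbon. The two measured steps both changed a group on an aromatic ring and both stayed within the scatter, so a change of no more than the scatter is expected for the phenyl substituent swap, a number 1 percentage points higher from compound 2 to compound 4 (within the scatter). Compound 4 is therefore estimated to give 18%, with a range from 8% to 30%.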

Compound 4, percent growth inhibition at one concentration: 25.2%
Beside the measured number, compound 4's estimate is 7.2 percentage points below it; measured number inside the range.
By their numbers in this assay, from the lowest: compounds 1, 2, 3 and 4 (each within the scatter of the next).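

Moving from 4-chlorophenyl to 3-methylphenyl on the carbon between the ring nitrogen and ring oxygen still gives only a small shift in this assay (a number 8.2 percentage points higher from compound 2 to compound 4 (within the scatter)). Adding the methyl to the plain phenyl of compound 1 gives the same kind of result (a number 9.5 percentage points higher from compound 1 to compound 4 (within the scatter)), so this phenyl ring has now carried a methyl as well as a chloro without any step beyond the scatter. No outside evidence explains these numbers. Still open, from the compounds shown here alone, is whether an amine, a carboxylic acid or a longer chain on this ring would produce a step beyond the scatter.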